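This account rests on a few compounds, and the source may have more. Where it says the series, first, only, none or still open, it means among the compounds named here.

Compound 1 `Cc1cc(NC(=O)c2cc(C(F)(F)F)cc(C(F)(F)F)c2)ccc1NS(C)(=O)=O`: > 250000 nM, which is a limit of the assay.
Compound 2 `CCS(=O)(=O)Nc1ccc(NC(=O)c2cc(C(F)(F)F)cc(C(F)(F)F)c2)cc1C`: 124000 nM
Compound 3 `Cc1cc(NC(=O)c2cc(C(F)(F)F)cc(C(F)(F)F)c2)ccc1NS(=O)(=O)C(F)(F)F`: 40700 nM

In an ADME assay on RAW264.7 cells (Mus musculus) for cytotoxicity, read by MTT assay, with a stated time of 48 h (a higher number here means a weaker inhibitor, a lower number a stronger inhibitor), compound 2 gives 124000 nM, the higher of the two exact numbers, and compound 3 lies below it. Compound 4 `CCS(=O)(=O)Nc1ccc(NC(=O)c2cc(C(F)(F)F)cc(C(F)(F)F)c2)cc1Cl` differs from compound 2 in one place: chloro in place of methyl on an aromatic carbon. Going by the values given here, no measured step makes this swap of chloro in place of methyl on an aromatic carbon. The closest guides changed the group on the sulfonyl sulfur instead: an at least 2.0-fold lower number from compound 1 to compound 2 (0.30 log units; that floor lies within the scatter), and a 3.0-fold lower number from compound 2 to compound 3 (0.48 log units; beyond the scatter). With only these to go on, the expectation is a slight lean toward a lower number, probably not beyond the scatter. The expected change is a 1.6-fold lower number from compound 2 to compound 4 (0.19 log units; within the scatter). The estimated value for compound 4 is 80000 nM, with an expected range from 30000 nM to 200000 nM.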

Compound 4, half-maximal inhibitory concentration: 64100 nM
Compound 4: middle estimate off by 1.2-fold (0.10 log units), on the high side; low and high end bracket the measured number.
By their numbers in this assay, from the lowest: compounds 3, 4 and 2 (each within the scatter of the next, the first and the last beyond it). At a limit, above all of these: compound 1.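

This is the first change shown on the aromatic ring rather than on the sulfonyl sulfur: with chloro in place of methyl, ortho to the (ethylsulfonyl)amino group, this assay gives a 1.9-fold lower number from compound 2 to compound 4 (0.29 log units; within the scatter). At this position, then, the swap leaves the two compounds within the scatter of each other, whereas trifluoromethyl in place of ethyl on the sulfonyl sulfur gave a step beyond it. Nothing measured here explains this result. Open, going by these compounds, is whether a methoxy group or a nitrile at this position would give a step beyond the scatter. Also open, on these data alone, is whether chloro gives a similar step when trifluoromethyl sits on the sulfonyl sulfur.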